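The source may hold more compounds than are shown below. What is called first, only, known or untested is meant among the compounds shown, and "the series" means these compounds.

Series notes. The shared core of compound 1 `O=C(NCCCNc1nc(Nc2cccc(F)c2)ncc1Br)c1ccc(C(F)(F)F)cc1` carries an amide at the end of the propyl chain; in an assay on isolated protein for inhibition of serine/threonine-protein kinase TBK1 (Homo sapiens) (a lower number here means a stronger inhibitor, a higher number a weaker inhibitor), compound 1 gives 450 nM, which places it second highest of the three numbers in hand. Compound 2 `O=C(NCCCNc1nc(Nc2cncnc2)ncc1C1CC1)C1CCC1` sits furthest up: in this assay compound 2 gives 3200 nM. Compound 3 `O=C(NCCCNc1nc(Nc2cnn(C3CC3)c2)ncc1C1CC1)C1CCC1` sits lowest of the three: in this assay compound 3 gives 10 nM. Within the data shown here, the one single-point step measured so far, a 320-fold lower number from compound 2 to compound 3 (2.51 log units; beyond the scatter), concerns the group on a nitrogen on an aromatic ring and not the amide.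

Compound 4 `O=C(CCc1ccccc1)NCCCNc1nc(Nc2cccc(F)c2)ncc1Br` is compound 1 with phenethyl in place of 4-(trifluoromethyl)phenyl on a carbonyl carbon. Among the measured compounds shown here, no measured step touches this carbonyl carbon. Compound 1 and compound 3 differ in several places at once, so their two values show only that a cyclobutyl amide can go with a low number when other parts of the molecule change as well. The step from compound 1 to compound 4 is therefore expected to stay close to the scatter, with a small rise if anything, and the expected step is a 1.3-fold higher number from compound 1 to compound 4 (0.12 log units; within the scatter). For compound 4 in this assay the estimate is 600 nM, with a range from 150 nM to 2500 nM.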

Compound 4, half-maximal inhibitory concentration: 560 nM
Compound 4: middle estimate off by 1.1-fold (0.03 log units), on the high side, and the stated range covers the measured number.
By their numbers in this assay, from the lowest: compound 3; then compounds 1 and 4 (each within the scatter of the next); then compound 2.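

Among these compounds, the step of a 1.2-fold higher number from compound 1 to compound 4 (0.09 log units; within the scatter) is the first measured at this carbonyl carbon in this assay and lies within the scatter. Phenethyl, with 8 heavy atoms, all carbon, thus takes the place of 4-(trifluoromethyl)phenyl, with 10 heavy atoms including 3 fluorine, without a readable change on the shared core of compound 1, although this is one pair and one kind of replacement. No measurement in hand offers an explanation for this result.

Going by these compounds, it remains open whether the same replacement would leave the number equally unchanged on the core of compound 3, which gives 10 nM and differs from compound 1 in several places. Also open, on these data alone, is how this carbonyl carbon would respond to a group of a different kind, such as a primary amine, a carboxylic acid or a longer carbon chain in place of phenethyl.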